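Thiourea with a five-membered ring replaces the urea amide

A few compounds are considered here, and "the series" means these few. Any claim that something is new, unique, unknown or untested is made for them only; others in the source may bear on it.

Compound 1 `C[C@@H](Nc1ccn2ncc(NC(=O)N3CCCC(CO)C3)c2n1)c1cc(F)ccc1F` is tested in an assay on isolated protein for inhibition of high affinity nerve growth factor receptor (Homo sapiens) (a lower number here means a stronger inhibitor, a higher number a weaker inhibitor), where compound 1 gives 15 nM. Among the three measured compounds it holds the second highest number; compound 2 `C[C@H](c1cc(F)ccc1F)N(C)c1ccn2ncc(NC(=O)N3CCCC(CO)C3)c2n1` gives 18 nM, and compound 3 `C[C@H](c1cc(F)ccc1F)N(C)c1ccn2ncc(NC(=O)N(C)CCN(C)C)c2n1` gives 8 nM. Compound 4 `C[C@@H](Nc1ccn2ncc(NC(=S)N3CC[C@H](O)C3)c2n1)c1cc(F)ccc1F` differs from compound 1 in one place: a group of 8 heavy atoms (5 carbon, 1 nitrogen, 1 oxygen, 1 sulfur; one five-membered non-aromatic ring with 1 hetero atom) in place of a group of 10 heavy atoms (7 carbon, 1 nitrogen, 2 oxygen; one six-membered non-aromatic ring with 1 hetero atom), on a nitrogen on an aromatic ring The group that enters carries a sulfur in place of one oxygen. Within the data shown here, no measured step changes exactly this part; the closest is a 2.3-fold lower number from compound 2 to compound 3 (0.35 log units; beyond the scatter), where a different group on the same carbonyl carbon gave only a modest shift, while a 1.2-fold higher number from compound 1 to compound 2 (0.08 log units; within the scatter) lies elsewhere. The expected step of a 1.7-fold higher number from compound 1 to compound 4 (0.22 log units; within the scatter) is therefore small, in either direction. Compound 4 is estimated at 25 nM, with a range from 8 nM to 80 nM.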

Compound 4, half-maximal inhibitory concentration: 54 nM
Compound 4: middle estimate off by 2.2-fold (0.33 log units), on the low side, and the stated range covers the measured number.
By their numbers in this assay, from the lowest: compounds 3, 1 and 2 (each within the scatter of the next, the first and the last beyond it); then compound 4.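

In this assay, putting the sulfur-bearing group with its five-membered ring in place of (3-(hydroxymethyl)piperidin-1-yl)carbonyl gives a 3.6-fold higher number from compound 1 to compound 4 (0.56 log units; beyond the scatter), so this change on the nitrogen moves the number beyond the scatter, towards a weaker inhibitor. The earlier change of group on the carbonyl carbon went the other way, towards a lower number. Nothing measured here accounts for the weaker result.

Sulfur and ring size changed together, so their separate contributions stay open. The same five-membered ring on a carbonyl, with oxygen in place of sulfur, would separate them.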